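Halogen swap on the benzyl arm of a triazole ether

The compounds below may be only part of what the source reports. "The series", "measured", "known", "first", "only" and "open" are said of these compounds alone.

compound 1 `Clc1ccc(Cn2cc(COc3ccc(Cl)cc3)nn2)cc1`: > 100 ug/mL
compound 2 `Clc1ccc(OCc2cn(Cc3cccc(Cl)c3)nn2)cc1`: > 100 ug/mL

In an ADME assay on PANC-1 cells (Homo sapiens) for inhibition, read by MTT assay, with a stated time of 48 h (on this read-out higher numbers stand for weaker inhibition of growth and lower numbers for stronger inhibition of growth), compound 1 gives > 100 ug/mL, which is a limit of the assay and not a number. Compound 2 likewise gives > 100 ug/mL, again only a limit. Among the compounds with values here, the single measured step, a step that the two limits leave unreadable from compound 1 to compound 2, thus tells nothing about size. Compound 3 `Clc1ccc(OCc2cn(Cc3ccc(Br)cc3)nn2)cc1` differs from compound 2 by 4-bromophenyl in place of 3-chlorophenyl on a saturated chain carbon bound to an aromatic nitrogen. Within the data shown here, no readable step bears on this change; the only evidence is the limit of > 100 ug/mL in this assay, at which 2 of the 2 values shown sit. The expected step that the limit leaves unreadable from compound 2 to compound 3 is therefore no change beyond the scatter. Compound 3 is estimated at 150 ug/mL, within a range from 60 ug/mL to 400 ug/mL, most likely reported once more as a limit.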

Compound 3, concentration for 50% growth inhibition: > 100 ug/mL
Compound 3: only a limit was reported; the forecaster's own chance of this, stated with the estimate: 85%; the middle value lies beyond the limit too.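

In this assay, within the data shown here, compound 1, compound 2 and compound 3 each give only a limit and not a number, so no step among them can be read. Going by these compounds, whether swapping chloro and bromo changes growth inhibition at all remains open.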